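The compounds below may be only part of what the source reports. "The series", "measured", "known", "first", "only" and "open" are said of these compounds alone.

In a functional assay on MCF7 cells (Homo sapiens) for antiproliferative activity, read by MTT assay (on this read-out lower numbers stand for stronger inhibition and higher numbers for weaker inhibition), two relatives of compound 3 have been tested so far. Compound 1 (`CCc1ccccc1-n1cc(COc2ccc(/C=C/C(=O)c3cc4c(cc3O)OC(C)(C)CC4)cc2)nn1`) is reported as "not active" (no number reported), with no number attached. Compound 2 (`Cc1c(-n2cc(COc3ccc(/C=C/C(=O)c4ccc5c(c4O)CCC(C)(C)O5)cc3)nn2)cccc1[N+](=O)[O-]`) gives 145000 nM, the only figure available, so there is no other number to rank it against. Compound 3 (`CCCCCCCCn1cc(COc2ccc(/C=C/C(=O)c3ccc4c(c3O)CCC(C)(C)O4)cc2)nn1`) differs from compound 2 in one place: octyl in place of 2-methyl-3-nitrophenyl on an aromatic nitrogen. Among the compounds with values here, no measured pair shows what such a swap does. The expectation therefore starts from compound 2 at 145000 nM and leans towards a small to moderate step to a lower number, meaning stronger inhibition, with much uncertainty. The estimated change is a 2.4-fold lower number from compound 2 to compound 3 (0.38 log units; beyond the scatter). Compound 3 is expected near 60000 nM, with an estimated range of 15000 nM to 200000 nM.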

Compound 3, half-maximal inhibitory concentration: "not active" (no number reported)
For compound 3 the study gives words and no number, and the estimate cannot be compared.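

Within the data shown here, compound 3 is reported in words only, so in this assay no step from compound 2 to compound 3 can be read. The compounds shown leave open how far octyl in place of 2-methyl-3-nitrophenyl shifts the number. No evidence here bears on this result.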